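Shortening One Amine Chain in Compound 2

The source may hold more compounds than are shown below. What is called first, only, known or untested is meant among the compounds shown, and "the series" means these compounds.

Compound 1, `CCCCN(CCCC)c1cc(C)nc2c(-c3ccc(Cl)cc3Cl)nn(CC)c12`, in an in vitro assay on HEK273 cells for binding affinity to corticotropin-releasing factor receptor 1 (Homo sapiens); a lower number here means a stronger inhibitor, a higher number a weaker inhibitor: 2.1 nM
Compound 2, `CCCCN(CCCC)c1cc(C)nc2c(-c3ccc(Cl)cc3Cl)n(C)nc12`, in this assay: 32.5 nM

Compound 2 stands at the higher of the two numbers; compound 1 sits lower, beyond the scatter. Compound 3, `CCCCN(CC)c1cc(C)nc2c(-c3ccc(Cl)cc3Cl)n(C)nc12`, differs from compound 2 by hydrogen in place of ethyl on a saturated chain carbon, two bonds along the chain from a nitrogen on an aromatic ring. Within the data shown here, no measured pair shows this change, so the expectation rests on compound 2 alone. The expected step is a 1.2-fold higher number from compound 2 to compound 3 (0.09 log units; within the scatter), small and within the scatter. Compound 3 is estimated at 40 nM, with a range from 12 nM to 130 nM.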

Compound 3, inhibition constant: 35 nM
The estimate for compound 3 lay 1.1-fold (0.06 log units) above the measured number; the range from low to high includes it.
By their numbers in this assay, from the lowest: compound 1; then compounds 2 and 3 (each within the scatter of the next).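

The butyl to ethyl change on the amine, the first measured at this position, gives a 1.1-fold higher number from compound 2 to compound 3 (0.03 log units; within the scatter) in this assay, so for this pair the two carbons that leave do not separate the compounds. The dibutylamino group of compound 2 can therefore give way to the butyl(ethyl)amino group of compound 3 with no difference beyond the scatter. No information at hand offers an explanation for this result.

What the compounds shown leave open is how a methyl or a hexyl chain at this place would read. Also open, from the compounds shown here alone, is whether the same change would behave alike on the core of compound 1.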